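The source may hold more compounds than are shown below. What is called first, only, known or untested is meant among the compounds shown, and "the series" means these compounds.

Measured so far in a functional assay on TK-10 cells (Homo sapiens) for inhibition, read by sulforhodamine B assay, with a stated time of 48 h; on this read-out higher numbers stand for weaker inhibition of growth and lower numbers for stronger inhibition of growth:
- compound 1 `CCOC(=O)[C@H](CCC(=O)O)NC(=O)c1ccc(Sc2nc3cc(N)cc(N)c3nc2-c2ccccc2)cc1`: 53700 nM
- compound 2 `Nc1cc(N)c2nc(-c3ccccc3)c(Sc3ccc(F)cc3)nc2c1`: < 100000 nM
- compound 3 `COc1cc(CNc2nc3cc(N)cc(N)c3nc2-c2ccccc2)cc(OC)c1OC`: 6310 nM

The three share a core and differ at the group carried on the sulfur or nitrogen attached to it. Compound 3 gives 6310 nM in this assay, and compound 1 gives 53700 nM, so compound 3 sits at the lower, more inhibitory end of the numbers shown. Compound 2 is a different case: its value in this assay is a limit and not a number, (the limit of < 100000 nM in this assay, at which 1 of the 3 values shown sits), so only the edge of the range is known for compound 2.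

Compound 4 `Nc1cc(N)c2nc(-c3ccccc3)c(Sc3ccc(Cl)c(Cl)c3)nc2c1` is not yet measured. It relates to compound 2 by a single change, (3,4-dichlorophenyl in place of 4-fluorophenyl on a sulfur). Within the data shown here, with compound 2 known only as a limit, no measured step stands behind this change, so the expectation rests on the spread of the other values. A modest move in this assay is expected, a step that the limit leaves unreadable from compound 2 to compound 4, toward stronger inhibition of growth rather than away from it. Compound 4 is therefore estimated at 30000 nM, within a range of 8000 nM to 100000 nM.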

Compound 4, concentration for 50% growth inhibition: 5890 nM
For compound 4 the middle estimate is 5.1-fold (0.71 log units) above the measured one; measured number below the stated range.
By their numbers in this assay, from the lowest: compounds 4 and 3 (each within the scatter of the next); then compound 1.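

Compound 2 is known only as a limit, so no step from it to compound 4 can be read: the limit of < 100000 nM in this assay, at which 1 of the 4 values shown sits.

The compounds shown leave open what 3,4-dichlorophenyl in place of 4-fluorophenyl on a sulfur does to inhibition of growth; no pair with two numbers carries that change.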